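The source may report more compounds than this note shows. Statements on the series, on what has been measured and on what is new or still open speak of the compounds shown alone.

Compound 1 `CCOc1ccc2c(=O)cc(CC)oc2c1CBr` in a functional assay on A549 cells (Homo sapiens) for antiproliferative activity, read by sulforhodamine B assay, with a stated time of 72 h; on this read-out lower numbers stand for stronger inhibition of growth and higher numbers for weaker inhibition of growth: > 32100 nM, a limit of the assay.
Compound 2 `CCc1cc(=O)c2ccc(OC(C)C)c(CBr)c2o1`: > 30700 nM, a limit of the assay.
Compound 3 `CCc1cc(=O)c2ccc(OCC(C)C)c(CBr)c2o1`: > 29400 nM, a limit of the assay.

Compound 1 thus stands at a limit only, as do the other two measured compounds, so no measured number places it anywhere within the set. The three measured steps, a step that the two limits leave unreadable from compound 1 to compound 2, a step that the two limits leave unreadable from compound 1 to compound 3 and a step that the two limits leave unreadable from compound 2 to compound 3, all concern the ether chain and are each left unreadable by the two limits, as recorded in the limit of > 32100 nM in this assay, at which 1 of the 3 values shown sits, the limit of > 30700 nM in this assay, at which 1 of the 3 values shown sits, and (the limit of > 29400 nM in this assay, at which 1 of the 3 values shown sits).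

Among the measured compounds shown here, compound 4 `CCOc1ccc2c(=O)cc(C(C)Br)oc2c1CBr` differs from compound 1 by bromo in place of hydrogen on a saturated chain carbon bound to an aromatic carbon and a saturated chain carbon, a change at a place that none of the measured steps touches. For the measured compounds named here, no measured step therefore bears on it directly, and the measured steps that exist give no readable size in either direction. Compound 4 is consequently expected to remain at or near the limit, with an expected step that the limit leaves unreadable from compound 1 to compound 4. The estimate for compound 4 is 40000 nM, in the range 8000 nM to 200000 nM.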

Compound 4, concentration for 50% growth inhibition: 19800 nM
Beside the measured number, compound 4's estimate is 2.0-fold (0.31 log units) above it, within the range that was stated.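

Among the compounds shown here, compound 4 is the first compound here to give a number rather than a limit in this assay, whereas the steps among compound 1, compound 2 and compound 3 on the ether chain cannot be read. The change from ethyl to 1-bromoethyl gives an at least 1.6-fold lower number from compound 1 to compound 4 (0.20 log units; that floor lies within the scatter), so this floor alone does not establish a real gain, although the true step may be larger. The step can be read only as a floor because compound 1 stands at a limit: the limit of > 32100 nM in this assay, at which 1 of the 4 values shown sits.

As far as these compounds go, whether an amine, a hydroxyl group or a longer chain on this saturated chain carbon would give a number like that of compound 4 remains open. So does whether the 1-bromoethyl group would give a readable value with the isopropyl or isobutyl ether of compound 2 and compound 3.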